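A few compounds are considered here, and "the series" means these few. Any claim that something is new, unique, unknown or untested is made for them only; others in the source may bear on it.

Compound 1 `C=CCn1c(=O)n(C2C=CC(CO)O2)c2nc(N)nc(O)c21` gives 6 uM in a functional assay (B cells) with Mus musculus as the target; on this read-out higher numbers stand for an effect only at larger amounts of compound and lower numbers for an effect already at smaller amounts. Compound 3 `CCCn1c(=O)n(C2C=CC(CO)O2)c2nc(N)nc(O)c21` gives 6 uM in this assay, and the step of no change at the digits printed from compound 1 to compound 3 (within the scatter) stays within the scatter, so compound 1 and compound 3 share the lowest numbers of the three. Compound 2 `CCOC(=O)Cn1c(=O)n(C2OC(CO)[C@@H](O)[C@H]2O)c2nc(N)nc(O)c21` gives 48 uM in this assay, a higher number than compound 1 that lies beyond the scatter. Compound 4 `C=CCn1c(=O)n(C2CCC(CO)C2)c2nc(N)nc(O)c21` differs from compound 1 by a group of 7 heavy atoms (6 carbon, 1 oxygen; one five-membered non-aromatic ring of carbon only) in place of a group of 7 heavy atoms (5 carbon, 2 oxygen; one five-membered non-aromatic ring with 1 hetero atom), on an aromatic nitrogen. For the measured compounds named here, no measured step touches this place: the only measured step sits on the allyl group and was flat, and compound 2 changes two places at once. The number for compound 4 is therefore expected near that of compound 1, with a 2.0-fold higher number from compound 1 to compound 4 (0.30 log units; within the scatter) as the estimated step. Compound 4 is estimated at 12 uM, expected between 3 uM and 50 uM.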

Compound 4, concentration for half-maximal effect: 226 uM
Compound 4: middle estimate off by 19-fold (1.27 log units), on the low side; the measured number lies above the stated range.
By their numbers in this assay, from the lowest: compounds 1 and 3 (each within the scatter of the next); then compound 2; then compound 4.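

The group on the aromatic nitrogen carries far more weight in this assay than the flat step on the allyl group suggested: placing the five-membered ring of carbon only there gives a 38-fold higher number from compound 1 to compound 4 (1.58 log units; beyond the scatter). This change removes the ring hetero atom and the double bond outside aromatic rings together, so the step belongs to the pair of changes and to neither alone. Nothing at hand explains the size of this step. The compounds shown leave open whether the ring oxygen or the double bond accounts for it. They also leave open how an amine in place of the ring-bound hydroxymethyl group would read out.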